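This account rests on a few compounds, and the source may have more. Where it says the series, first, only, none or still open, it means among the compounds named here.

Working notes on a small set of carbamates built on one shared core. Compound 1 `CCOC(=O)Nc1cc(C)n(Cc2cc(Cl)ccc2OCc2ccccc2)n1` and compound 2 `COC(=O)Nc1cc(C)n(Cc2cc(Cl)ccc2OCc2ccccc2)n1` differ in one place only: hydrogen in place of methyl on a saturated chain carbon bound to an oxygen next to a carbonyl group. In an assay on CHO-K1 cells for displacement of a labelled ligand from prostaglandin E2 receptor EP1 subtype (Homo sapiens) (a higher number here means a weaker inhibitor, a lower number a stronger inhibitor), compound 1 gives 79.4 nM, and compound 2 gives 200 nM; the change reads as a 2.5-fold higher number from compound 1 to compound 2 (0.40 log units; beyond the scatter). Compound 3 `Cc1cc(NC(=O)OC(C)(C)C)nn1Cc1cc(Cl)ccc1OCC(C)C` differs from compound 1 in more than one place, and the difference between the two cores is not broken down here. In this assay compound 3 gives 31.6 nM, the lowest number among the three measured compounds.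

Compound 4 `Cc1cc(NC(=O)OC(C)C)nn1Cc1cc(Cl)ccc1OCC(C)C` has not yet been measured. It differs from compound 3 by hydrogen in place of methyl on a saturated chain carbon bound to an oxygen next to a carbonyl group and two saturated chain carbons. Among the measured compounds shown here, this is the same kind of change as the one from compound 1 to compound 2, not the same change: in compound 3 the carbon that carries it is bound to an oxygen next to a carbonyl group and two saturated chain carbons, whereas in compound 1 it is bound only to an oxygen next to a carbonyl group. For the measured compounds named here, only one instance of this kind of change has been measured, so no pattern can be claimed beyond that pair. Going by the values given here, for compound 4 in this assay a step of similar or somewhat larger size is expected, a 2.5-fold higher number from compound 3 to compound 4 (0.40 log units; beyond the scatter), because a 2.5-fold higher number from compound 1 to compound 2 (0.40 log units; beyond the scatter) is the only comparable step available. Compound 4 is estimated at 80 nM, with an expected range from 35 nM to 200 nM.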

Compound 4, half-maximal inhibitory concentration: 50.1 nM
Compound 4: middle estimate off by 1.6-fold (0.20 log units), on the high side; measured number inside the range.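

In this assay, the change from tert-butoxycarbonyl to isopropoxycarbonyl, with hydrogen in place of methyl on the carbon bound to an oxygen next to a carbonyl group and two saturated chain carbons, reads as a 1.6-fold higher number from compound 3 to compound 4 (0.20 log units; within the scatter), so on this core the step cannot be told apart from repeat measurement. This does not show that the change carries reliably from core to core in this series: the evidence is two pairs only, the carbon carrying the change has a different substitution in each, and the cores differ in more than one place. What can be said is limited to these pairs, whose steps fall on different sides of the scatter yet cannot be told apart from each other, so the earlier step gave a usable first guide here and nothing more general follows from the comparison of the two cores: the same change on two cores in this assay, a 2.5-fold higher number (0.40 log units; beyond the scatter) from compound 1 to compound 2 and a 1.6-fold higher number (0.20 log units; within the scatter) from compound 3 to compound 4, 1.6-fold (0.20 log units) apart, within the scatter of two such steps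

Still open, as far as these compounds go, is whether the same tert-butoxycarbonyl to isopropoxycarbonyl change on the core of compound 1 would give a step of similar size, which would separate the effect of the core from that of the carbamate chain. Also open, from the compounds shown here alone, is how this series would read with a longer chain or a cyclopropyl group on the carbamate oxygen, or with an amide in place of the carbamate.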